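Antiproliferative activity on a new aryl substituent at the pyrazole

The source may report more compounds than this note shows. Statements on the series, on what has been measured and on what is new or still open speak of the compounds shown alone.

Measured compounds:
compound 1, `Cc1ccccc1-c1c(C)nn(-c2nc(-c3ccc(Cl)c(Cl)c3)c(SC(C)C)s2)c1C(=O)O`, 5500 nM
compound 2, `Cc1nn(-c2nc(-c3ccc(Cl)c(Cl)c3)c(SC(C)C)s2)c(C(=O)O)c1-c1cncnc1`, 22000 nM

Of the compounds shown here, two sharing one core have been tested in a functional assay on BJAB cells (Homo sapiens) for antiproliferative activity, with a stated time of 4 days; a lower number here means that less compound is needed, a higher number that more compound is needed for the effect. Compound 1 carries a 2-methylphenyl group and gives 5500 nM. Going by the values given here, compound 2 carries a pyrimidin-5-yl group in that place and gives 22000 nM; compound 2 therefore stands at the higher of the two numbers, the single step being a 4.0-fold higher number from compound 1 to compound 2 (0.60 log units; beyond the scatter).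

The next compound, compound 3, `COc1ccccc1-c1c(C)nn(-c2nc(-c3ccc(Cl)c(Cl)c3)c(SC(C)C)s2)c1C(=O)O`, differs from compound 2 in one place: 2-methoxyphenyl in place of pyrimidin-5-yl on an aromatic carbon. Among the compounds with values here, the only measured step that bears on this change is the one from compound 1 to compound 2, where exchanging 2-methylphenyl for pyrimidin-5-yl gave a 4.0-fold higher number from compound 1 to compound 2 (0.60 log units; beyond the scatter). Compound 3 returns to a phenyl group bearing a small substituent in the same position as in compound 1, so a reversal of that step is expected, which in this assay means a lower number for compound 3 than for compound 2.

Compound 3 is therefore expected to land near compound 1, with an estimated value of 6500 nM in this assay, in a range from 2500 nM to 17000 nM, corresponding to an expected step of a 3.4-fold lower number from compound 2 to compound 3 (0.53 log units; beyond the scatter).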

Compound 3, half-maximal effective concentration: 14700 nM
Compound 3: middle estimate off by 2.3-fold (0.35 log units), on the low side, within the range that was stated.
By their numbers in this assay, from the lowest: compound 1; then compounds 3 and 2 (each within the scatter of the next).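

In this assay, the exchange that yields compound 3 gives a 1.5-fold lower number from compound 2 to compound 3 (0.18 log units; within the scatter), so 2-methoxyphenyl and pyrimidin-5-yl cannot be told apart at this place on the pyrazole. The earlier step had suggested that a phenyl group bearing a small substituent might be what separated compound 1 from compound 2, but an aromatic ring of carbon only does not by itself bring the number back to that of compound 1. The direct comparison of the two phenyl compounds, methoxy in place of methyl on an aromatic carbon, gives a 2.7-fold higher number from compound 1 to compound 3 (0.43 log units; beyond the scatter), which shows that this assay responds to the small substituent on the phenyl ring as well as to the ring that carries it.

The compounds shown leave open how an unsubstituted phenyl group would compare, and whether a chlorine, an amine or a longer chain such as ethoxy on the phenyl ring would follow methyl or methoxy. With three compounds, they also leave open whether any group at this place can give a lower number than compound 1 does. No evidence at hand accounts for either step.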